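The source may report more compounds than this note shows. Statements on the series, on what has been measured and on what is new or still open speak of the compounds shown alone.

Compound 1 `O=C(NO)c1cccc(-c2cn([C@@H]3C[C@@H](CO)N(Cc4ccccc4)C3)nn2)c1` and compound 2 `O=C(NO)c1cccc(-c2cn([C@@H]3C[C@@H](CO)N(CCCc4ccccc4)C3)nn2)c1` share one core and differ only in the change (phenethyl in place of phenyl on a saturated chain carbon bound to an amine nitrogen in a ring). In an assay on Sf9 cells for inhibition of histone deacetylase 11 (Homo sapiens), read by fluorescence, tested at 0.5 uM (a higher number here means more inhibition at the concentration tested (going by the name of the read-out), a lower number less inhibition), compound 1 gives only a limit, < 10%. Compound 2 also gives only a limit in this assay, < 10%. The step that the two limits leave unreadable from compound 1 to compound 2 is therefore not readable, since both values rest at the limit of < 10% in this assay, at which 2 of the 3 values shown sit. Compound 3 `O=C(/C=C/c1cn([C@H]2C[C@H](CO)N(Cc3ccccc3)C2)nn1)NO` has a different core; how it differs from the core of compound 1 is not broken down here. In this assay, among the compounds with values here, compound 3 gives 20%, the only number among the three values shown. Compound 4 `O=C(/C=C/c1cn([C@H]2C[C@H](CO)N(CCCc3ccccc3)C2)nn1)NO` carries the same kind of change made on compound 3, (phenethyl in place of phenyl on a saturated chain carbon bound to an amine nitrogen in a ring). The step that the two limits leave unreadable from compound 1 to compound 2 offers no readable size to carry over, so the expectation for compound 4 rests on the value of compound 3 alone. Compound 4 is expected to stay near compound 3, with an estimated step of a number 5 percentage points lower from compound 3 to compound 4 (within the scatter). Compound 4 is thus estimated at 15%, within 0% to 30%.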

Compound 4, a percentage reported as inhibition, at one concentration (the size of the read-out at that concentration, not a potency): 16%
Compound 4: middle estimate off by 1 percentage points, on the low side; measured number inside the range.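

In this assay, replacing phenyl with phenethyl on a saturated chain carbon bound to an amine nitrogen in a ring gives a step of a number 4 percentage points lower from compound 3 to compound 4 (within the scatter), so on this core the two compounds cannot be told apart. The same change on the core of compound 1 cannot be read, because both values there are limits and not numbers: the limit of < 10% in this assay, at which 2 of the 4 values shown sit. This leaves a single readable step, so the series shows nothing about whether the change behaves alike on both cores, and the result on the core of compound 3 cannot be carried over to the core of compound 1.

The compounds shown leave open how either core would read with a carboxylic acid or an amine in place of the phenyl, or with a chain longer than 3-phenylpropyl. They also leave open how these compounds would compare as a matter of potency, since each reading comes from one concentration only.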